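The compounds below may be only part of what the source reports. "The series", "measured", "known", "first", "only" and "open" are said of these compounds alone.

Measured so far:
Compound 1 `Cc1ccc(/C(=C\CC(N)C(=O)O)c2ccc(F)cc2F)cc1` gives 9560 nM in a functional assay for inhibition of sodium- and chloride-dependent glycine transporter 1 (Rattus norvegicus), with a stated time of 30 min, in the presence of a further agent that is not named here; on this read-out higher numbers stand for weaker inhibition and lower numbers for stronger inhibition.
Compound 2 `COc1ccc(/C(=C/CC(N)C(=O)O)c2ccc(C(C)C)cc2)cc1` gives > 10000 nM in this assay, which is a limit of the assay and not a number.

Within the data shown here, compound 1 therefore holds the only numeric value shown in this assay; the other entry sits at the limit of > 10000 nM in this assay, at which 1 of the 2 values shown sits. Compound 3 `NC(C/C=C(\c1ccccc1)c1ccc(F)cc1F)C(=O)O` differs from compound 1 by hydrogen in place of methyl on an aromatic carbon, para to a large group, or 4-methylphenyl to phenyl. Among the measured compounds shown here, no measured pair shows this change, so the step of a 1.4-fold higher number from compound 1 to compound 3 (0.13 log units; within the scatter) is expected to be small, within or only slightly beyond the scatter, if anything toward weaker inhibition. Compound 3 is estimated at 13000 nM, in the range 5000 nM to 35000 nM.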

Compound 3, half-maximal inhibitory concentration: 9500 nM
For compound 3 the middle estimate is 1.4-fold (0.14 log units) above the measured one; the range from low to high includes it.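

In this assay, hydrogen in place of methyl on an aromatic carbon gives a 1.0-fold lower number from compound 1 to compound 3 (0.00 log units; within the scatter). Among these compounds, this is the only measured pair, and at this place, para to a large group, it does not tell methyl and hydrogen apart. Among the compounds shown here, compound 2 holds a limit of the assay and not a number, so no step to it can be read: the limit of > 10000 nM in this assay, at which 1 of the 3 values shown sits.

From the compounds shown here alone, whether an amine, a carboxylic acid or a longer chain at this place would give a step beyond the scatter stays open.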